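A few compounds are considered here, and "the series" means these few. Any claim that something is new, unique, unknown or untested is made for them only; others in the source may bear on it.

Measured compounds: compound 1 `C[C@@H](NCc1ccc(OCc2ccccc2)cc1)C(N)=O`, 23.8 mg/kg; compound 2 `NC(=O)[C@@H](CO)NCc1ccc(OCc2ccccc2)cc1`, 133 mg/kg.

In a functional assay on the whole organism with Mus musculus as the target (on this read-out lower numbers stand for an effect already at smaller amounts and higher numbers for an effect only at larger amounts of compound), compound 2 stands at the highest of the two numbers, with compound 1 as its nearest neighbour. Compound 3 `CNC(=O)[C@H](NCc1ccc(OCc2ccccc2)cc1)C(C)C` differs from compound 2 by 2-methyl-1-(methylcarbamoyl)propyl in place of 1-carbamoyl-2-hydroxyethyl on an amine nitrogen. Among the measured compounds shown here, the only measured step that bears on this change is a 5.6-fold higher number from compound 1 to compound 2 (0.75 log units; beyond the scatter); compound 3 again lacks the hydroxy, so a step back toward the number of compound 1 is expected, roughly a 4.4-fold lower number from compound 2 to compound 3 (0.65 log units; beyond the scatter). Compound 3 is therefore estimated at 30 mg/kg in this assay, with a range from 10 mg/kg to 100 mg/kg.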

Compound 3, dose for half-maximal effect: 112 mg/kg
The estimate for compound 3 lay 3.7-fold (0.57 log units) below the measured number; the measured number lies above the stated range.
By their numbers in this assay, from the lowest: compound 1; then compounds 3 and 2 (each within the scatter of the next).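

In this assay, 2-methyl-1-(methylcarbamoyl)propyl in place of 1-carbamoyl-2-hydroxyethyl on the amine nitrogen shifts the number only within the scatter (a 1.2-fold lower number from compound 2 to compound 3 (0.07 log units; within the scatter)). Measured against 1-carbamoylethyl, the same group gives a clear step (a 4.7-fold higher number from compound 1 to compound 3 (0.67 log units; beyond the scatter)), so the absence of the hydroxy does not by itself bring a compound close to compound 1. Nothing at hand gives a cause for this. The compounds shown leave open whether the methyl on the carbamoyl or the 2-methyl branching carries that step. They also leave open how a carboxylic acid in place of the carbamoyl would read.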